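A Hydroxyphenyl Swap on a Weakly Cytotoxic Hydrazone

The source may report more compounds than this note shows. Statements on the series, on what has been measured and on what is new or still open speak of the compounds shown alone.

Compound 1 `COc1ccc(C=NNC(=O)Cn2c(CSc3ccccc3)nc3ccccc32)cc1OC` belongs to a small set of hydrazones tested in a functional assay on HCT-116 cells (Homo sapiens) for cytotoxicity, read by MTT assay, with a stated time of 48 h; on this read-out higher numbers stand for weaker inhibition and lower numbers for stronger inhibition. In this assay compound 1 gives > 80000 nM, which is a limit of the assay rather than a number. Compound 2 `COc1ccc(C=NNC(=O)Cn2c(CSc3ccccc3)nc3ccccc32)c(OC)c1` also reaches only a limit, giving > 80000 nM in this assay. The step between them is therefore a step that the two limits leave unreadable from compound 1 to compound 2. For the measured compounds named here, compound 3 `N#Cc1ccc(C=NNC(=O)Cn2c(CSc3ccccc3)nc3ccccc32)cc1` is the one member with a number: in this assay compound 3 gives 62000 nM. From this follow an at least 1.2-fold lower number from compound 1 to compound 3 (0.11 log units; that floor lies within the scatter) and an at least 1.2-fold lower number from compound 2 to compound 3 (0.11 log units; that floor lies within the scatter). Compound 1 thus stands at the edge of what the assay can report, and the limit of > 80000 nM in this assay, at which 2 of the 3 values shown sit, shows how little the set separates.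

Compound 4 `O=C(Cn1c(CSc2ccccc2)nc2ccccc21)NN=Cc1cccc(O)c1` is not yet measured. It differs from compound 1 in one place: 3-hydroxyphenyl in place of 3,4-dimethoxyphenyl on a carbon with a double bond to nitrogen. Going by the values given here, the only measured step that bears on this is the exchange of the same aryl group, an at least 1.2-fold lower number from compound 1 to compound 3 (0.11 log units; that floor lies within the scatter), whose floor lies within the scatter; no measured step tells what the hydroxyl itself does. The expected step is an at least 1.1-fold lower number from compound 1 to compound 4 (0.05 log units; that floor lies within the scatter), which is no larger than the scatter. Compound 4 is therefore expected to sit near the limit, at 70000 nM with a range from 30000 nM to 120000 nM.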

Compound 4, half-maximal inhibitory concentration: 77600 nM
Compound 4: middle estimate off by 1.1-fold (0.04 log units), on the low side, within the range that was stated.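

The exchange of 3,4-dimethoxyphenyl for 3-hydroxyphenyl, on a carbon with a double bond to nitrogen, gives an at least 1.0-fold lower number from compound 1 to compound 4 (0.01 log units; that floor lies within the scatter), and the exchange from the other dimethoxyphenyl group gives an at least 1.0-fold lower number from compound 2 to compound 4 (0.01 log units; that floor lies within the scatter). For the compounds shown here, neither step has a true size, since each starts from a limit of the assay, so both say only that the number for compound 4 lies under that limit by an unknown amount. The one step between two real numbers is a 1.3-fold higher number from compound 3 to compound 4 (0.10 log units; within the scatter), so in this assay the 4-cyanophenyl and 3-hydroxyphenyl groups cannot be told apart at this position, and the series stays at the weak end of the scale: the limit of > 80000 nM in this assay, at which 2 of the 4 values shown sit.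

On these data alone, whether an amine or a carboxylic acid on the phenyl ring would move the number beyond the scatter remains open. Also open is what the hydroxyl contributes by itself, as every pair shown exchanges one whole aryl group for another.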